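One Methyl More: What Compound 4 Might Give

This account rests on a few compounds, and the source may have more. Where it says the series, first, only, none or still open, it means among the compounds named here.

In an assay on COS-7 cells for inhibition of patatin-like phospholipase domain-containing protein 2 (Mus musculus) (on this read-out higher numbers stand for weaker inhibition and lower numbers for stronger inhibition), compound 1 `CCNS(=O)(=O)c1cccc(-c2ccc(OCC)cc2)c1` gives 200000 nM. Compound 2 `CCOc1ccc(-c2cccc(S(=O)(=O)NC)c2)cc1` gives 200000 nM. The change methyl in place of hydrogen on a saturated chain carbon bound to a sulfonamide nitrogen brought no change at the digits printed from compound 2 to compound 1 (within the scatter). Compound 3 `CCOC(=O)Nc1cccc(-c2ccc(N(C)C)cc2)c1` gives 3000 nM; how its core differs from the core of compound 2 is not broken down here. Compound 4 `CC(C)OC(=O)Nc1cccc(-c2ccc(N(C)C)cc2)c1` has not yet been measured and carries the change (methyl in place of hydrogen on a saturated chain carbon bound to an oxygen next to a carbonyl group and a saturated chain carbon). This is the same kind of change as in the earlier pair, but the place differs: there the methyl entered on a saturated chain carbon bound to a sulfonamide nitrogen, here on a saturated chain carbon bound to an oxygen next to a carbonyl group and a saturated chain carbon. The step is expected to be small, no change at the digits printed from compound 3 to compound 4 (within the scatter), because the earlier pair gave no change at the digits printed from compound 2 to compound 1 (within the scatter). Compound 4 is therefore estimated at 3000 nM, likely between 1000 nM and 9000 nM.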

Compound 4, half-maximal inhibitory concentration: 82000 nM
Beside the measured number, compound 4's estimate is 27-fold (1.44 log units) below it, and the stated range ends below it.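

In this assay, the methyl that turns ethoxy into isopropoxy gave a 27-fold higher number from compound 3 to compound 4 (1.44 log units; beyond the scatter). The same kind of change therefore did not behave alike on the two cores: the same change on two cores in this assay, no change at the digits printed (within the scatter) from compound 2 to compound 1 and a 27-fold higher number (1.44 log units; beyond the scatter) from compound 3 to compound 4, 27-fold (1.44 log units) apart, beyond the scatter of two such steps. This shows that a silent methyl on one core was a poor guide to the same change on another here, but two pairs that also differ in where the methyl sits cannot show why the steps part, or how such a change would behave on any further core.

The compounds shown leave open what a longer chain such as propoxy would give in place of ethoxy on the core of compound 3. They also leave open whether a cyclopropyl group or an amine at that spot would give a number nearer to that of compound 3 or of compound 4.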